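Adding a methoxycarbonyl group to the triazolopyrimidine of compound 2

This account rests on a few compounds, and the source may have more. Where it says the series, first, only, none or still open, it means among the compounds named here.

Of the compounds shown here, three have been tested in a functional assay on PBMC cells (Homo sapiens) for antiproliferative activity; a lower number here means a stronger inhibitor, a higher number a weaker inhibitor. Compound 1 `Cc1cc2nnc(C(=O)N3CCC(c4nc(C(=O)NC5CCN(Cc6ccccc6)C5)cs4)CC3)c(C)n2n1` gives 37000 nM, compound 2 `O=C(c1ccccc1)c1ccc2[nH]c(NC(=O)c3csc(C4CCN(c5ccnc6ncnn56)CC4)n3)nc2c1` gives 3600 nM, and compound 3 `O=C(c1ccccc1)c1ccc2[nH]c(NC(=O)c3csc(C4CCN(c5ncnc6ccsc56)CC4)n3)nc2c1` gives 2200 nM. Compound 2 thus stands second highest of the three numbers; its nearest neighbour is compound 3, with a 1.6-fold lower number from compound 2 to compound 3 (0.21 log units; within the scatter), while compound 1 is furthest away, at a much higher number. Compound 4 `COC(=O)c1nc2nccc(N3CCC(c4nc(C(=O)Nc5nc6cc(C(=O)c7ccccc7)ccc6[nH]5)cs4)CC3)n2n1` differs from compound 2 in one place: methoxycarbonyl in place of hydrogen on an aromatic carbon, on an aromatic carbon of a five-membered aromatic ring that is part of a fused system of two rings, between two ring nitrogen atoms. For the measured compounds named here, no measured step concerns such an addition; the only measured step swaps one bicyclic ring system for another. The expectation is therefore a step of no change at the digits printed from compound 2 to compound 4 (within the scatter), nothing beyond the scatter. Compound 4 is estimated at 3600 nM, within 1200 nM to 11000 nM.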

Compound 4, half-maximal inhibitory concentration: 2500 nM
Estimate against measurement, compound 4: 1.4-fold (0.16 log units) above; measured number inside the range.
By their numbers in this assay, from the lowest: compounds 3, 4 and 2 (each within the scatter of the next); then compound 1.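

Placing methoxycarbonyl in place of hydrogen on this aromatic carbon, between two ring nitrogen atoms, gives a 1.4-fold lower number from compound 2 to compound 4 (0.16 log units; within the scatter) in this assay and so stays within the usual scatter. The earlier compounds shown here showed swaps of one whole ring system for another, whereas this step changes a single position on the ring system of compound 2. At this position, a group with no ring and a double bond outside aromatic rings can replace hydrogen without a change beyond the scatter.

From the compounds shown here alone, whether a carboxylic acid or an amine on the same carbon would give a similar number remains open. No measurement available here offers an explanation for this result.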